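Series notes: from compound 3 to compound 4

This account rests on a few compounds, and the source may have more. Where it says the series, first, only, none or still open, it means among the compounds named here.

Measured in a functional assay on A2780 cells (Homo sapiens) for antiproliferative activity, read by resazurin assay, with a stated time of 72 h; on this read-out higher numbers stand for weaker inhibition and lower numbers for stronger inhibition:
- compound 1 `CN(Cc1ccccc1)C(=O)c1cc2c(Cc3ccccc3)n[nH]c2cc1O`: 980 nM
- compound 2 `CN(Cc1ccccc1)C(=O)c1cc2c(Cc3ccccc3Cl)n[nH]c2cc1O`: "not determined" (no result reported)
- compound 3 `Cc1cccc(Cc2n[nH]c3cc(O)c(C(=O)N(C)Cc4ccccc4)cc23)c1`: 490 nM

Compound 3 gives 490 nM, within the scatter of compound 1 at 980 nM. Compound 2 adds no comparison, with "not determined" (no result reported) as its entry. Compound 4 `Cc1cccc(Cc2n[nH]c3cc(O)c(C(=O)N(C)Cc4ccc(Cl)c(F)c4)cc23)c1` keeps the rest of compound 3 and carries 4-chloro-3-fluorophenyl in place of phenyl on a saturated chain carbon bound to an amide-type nitrogen.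

For the measured compounds named here, only one measured step exists, a 2.0-fold lower number from compound 1 to compound 3 (0.30 log units; within the scatter), and it is methyl in place of hydrogen on an aromatic carbon, a different change. It bears on this one only as a sign of how small a step has been seen so far. Going by the values given here, no measured compound varies the benzyl group on the amide-type nitrogen, so the data give no firm direction in this assay. The expected change is no step beyond the scatter, with a slight lean towards a lower number: a 1.4-fold lower number from compound 3 to compound 4 (0.15 log units; within the scatter) is the estimated step. For compound 4 the expected value is 350 nM, with an estimated range of 100 nM to 1200 nM.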

Compound 4, half-maximal inhibitory concentration: 930 nM
Estimate against measurement, compound 4: 2.7-fold (0.42 log units) below; the range from low to high includes it.
By their numbers in this assay, from the lowest: compounds 3, 4 and 1 (each within the scatter of the next).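

In this assay, for the compounds shown here, the change from benzyl to 4-chloro-3-fluorobenzyl on the amide-type nitrogen gives a 1.9-fold higher number from compound 3 to compound 4 (0.28 log units; within the scatter), the first reading at this position. For this one pair, the position accepts the two added halogen atoms with no step beyond the scatter, so the benzyl group can be substituted in this way without a clear loss or gain. No measured data bear on the reason for this result.

Going by these compounds, it remains open whether chlorine or fluorine alone would behave the same way at this position, and whether a basic amine or a carboxylic acid on the benzyl ring would give a step beyond the scatter. On these data alone, a longer chain in place of benzyl, or a pyridine ring in place of its phenyl ring, is equally open.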